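The compounds below may be only part of what the source reports. "The series", "measured", "known", "first", "only" and "open" are said of these compounds alone.

Compound 1 `CC1CCN(C2CCN(S(=O)(=O)c3ccc(Br)c(Cl)c3)CC2)CC1`: > 5000 nM (a limit)
Compound 2 `Cc1nc(Cl)sc1S(=O)(=O)N1CCC(N2CCC(C)CC2)CC1`: > 10000 nM (a limit)

In an ADME assay on HCT-116 cells (Homo sapiens) for cytotoxicity, read by CellTiter-Glo, with a stated time of 72 h (a higher number here means a weaker inhibitor, a lower number a stronger inhibitor), compound 2 gives > 10000 nM, which is a limit and not a number. Compound 1 gives > 5000 nM, which is also a limit. Neither compound therefore has a measured value to serve as a firm starting point.

Compound 3 `CC1CCN(C2CCN(S(=O)(=O)c3ccc(Cl)cc3Cl)CC2)CC1` has yet to be measured. It carries 2,4-dichlorophenyl in place of 2-chloro-4-methyl-1,3-thiazol-5-yl on a sulfonyl sulfur.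

For the measured compounds named here, only one measured step bears on this change. It is a step that the two limits leave unreadable from compound 1 to compound 2, and it introduced the group that now leaves, in place of 4-bromo-3-chlorophenyl. Its size and direction cannot be read. Compound 1 is the nearer guide, as it also has a halogen-bearing phenyl on the sulfonyl sulfur, and its > 5000 nM is a limit. A similarly weak result, quite possibly another limit, is therefore expected in this assay.

The estimated change is an at least 1.2-fold lower number from compound 2 to compound 3 (0.09 log units; that floor lies within the scatter), and its direction is not firm. The expected value for compound 3 is 8000 nM, with an estimated range of 3000 nM to 20000 nM.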

Compound 3, half-maximal inhibitory concentration: > 5000 nM
Compound 3 was reported as a limit; the forecaster's own chance of this, stated with the estimate: 75%; the middle value does not contradict the limit.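

Compound 1, compound 2 and compound 3 are each reported only as a limit in this assay, so no step among them can be read: the limit of > 5000 nM in this assay, at which 2 of the 3 values shown sit.

The compounds shown leave open what the actual value of any of them is in this assay, and whether changing the group on the sulfonyl sulfur moves that value at all.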